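The compounds below may be only part of what the source reports. "The series", "measured", "known", "first", "only" and "open" are said of these compounds alone.

Measured so far:
compound 1, `COC(=O)c1sc2cc(-c3ccsc3)cnc2c1N`: 12100 nM
compound 2, `COC(=O)c1sc2cc(-c3ccc4ccccc4c3)cnc2c1N`: 95600 nM

Both compounds were tested in a functional assay on A-375 cells (Homo sapiens) for inhibition, read by sulforhodamine B assay, with a stated time of 48 h; a lower number here means a stronger inhibitor of growth, a higher number a weaker inhibitor of growth. Compound 1 gives 12100 nM, the lower of the two numbers, while compound 2 gives 95600 nM, a gap that lies beyond the scatter of repeated measurements. Compound 3, `COC(=O)c1sc2cc(-c3ccc(N)cc3)cnc2c1N`, has not yet been measured in this assay. It differs from compound 1 in one place: 4-aminophenyl in place of thiophen-3-yl on an aromatic carbon. Going by the values given here, no measured pair shows this exact exchange, and the one other compound measured is a weaker growth inhibitor than compound 1, so a change here need not preserve the result of compound 1. In this assay a modest step is expected, most likely toward a somewhat weaker growth inhibitor or no change beyond the scatter. Compound 3 is estimated at 16000 nM, within a range of 4000 nM to 60000 nM. That estimate amounts to an expected step of a 1.3-fold higher number from compound 1 to compound 3 (0.12 log units; within the scatter).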

Compound 3, concentration for 50% growth inhibition: 80800 nM
Beside the measured number, compound 3's estimate is 5.1-fold (0.70 log units) below it, outside the stated range (above it).
By their numbers in this assay, from the lowest: compound 1; then compounds 3 and 2 (each within the scatter of the next).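

In this assay the exchange of thiophen-3-yl for 4-aminophenyl on this aromatic carbon brings a 6.7-fold higher number from compound 1 to compound 3 (0.82 log units; beyond the scatter) and so a clear loss of growth inhibition, which shows that this position does not accept every aromatic group equally. Compound 3 at 80800 nM and compound 2 at 95600 nM lie within the scatter of each other, and compound 1 keeps the lowest number of the three. Nothing available explains this step.

Going by these compounds, the step changes the ring and adds the amine at once, so the share of each stays open. Plain phenyl would separate the two, and furan-3-yl or thiophen-2-yl would show how closely the result of compound 1 depends on thiophen-3-yl itself.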